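Chloro to Bromo: Expected Hindlimb Dose for Compound 3

A few compounds are considered here, and "the series" means these few. Any claim that something is new, unique, unknown or untested is made for them only; others in the source may bear on it.

Measured compounds:
compound 1, `CC(C)(C)c1ccc(C(=O)NN2C(=O)NC3(CC3(C)C)C2=O)cc1`, 100 mg/kg
compound 2, `CC1(C)CC12NC(=O)N(NC(=O)c1ccc(Cl)cc1)C2=O`, 300 mg/kg

In a functional assay on the whole organism (Hindlimb) for inhibition, with Mus musculus as the target, with a stated time of 4 h (a lower number here means that less compound is needed, a higher number that more compound is needed for the effect), compound 2 gives 300 mg/kg, the higher of the two numbers recorded so far. For the measured compounds named here, its nearest neighbour is compound 1, which in this assay gives 100 mg/kg; the one measured step, a 3.0-fold higher number from compound 1 to compound 2 (0.48 log units; beyond the scatter), is a modest step that lies beyond the scatter and follows from chloro in place of tert-butyl on an aromatic carbon.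

Compound 3, `CC1(C)CC12NC(=O)N(NC(=O)c1ccc(Br)cc1)C2=O`, differs from compound 2 by bromo in place of chloro on an aromatic carbon. Going by the values given here, only one measured step exists, a 3.0-fold higher number from compound 1 to compound 2 (0.48 log units; beyond the scatter), and it exchanges tert-butyl for chloro rather than chloro for bromo, so it bears on the new step only loosely: it shows that a para substituent of this kind can shift the dose by a modest amount, but no measured compound carries bromo. With one halogen replacing another at the same place, the step from compound 2 to compound 3 is expected to stay within the scatter, in either direction.

Compound 3 is therefore estimated at 300 mg/kg in this assay, with a range from 100 mg/kg to 1000 mg/kg. The expected step is no change at the digits printed from compound 2 to compound 3 (within the scatter).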

Compound 3, minimum effective dose: 300 mg/kg
Compound 3: middle estimate and measured number agree at the digits printed; measured number inside the range.
By their numbers in this assay, from the lowest: compound 1; then compounds 2 and 3 (each within the scatter of the next).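

In this assay the change from 4-chlorophenyl to 4-bromophenyl gives no change at the digits printed from compound 2 to compound 3 (within the scatter) and so, on this aromatic carbon para to a large group, the two halogens cannot be told apart by this read-out. The change away from tert-butyl now has a second example, with a 3.0-fold higher number from compound 1 to compound 3 (0.48 log units; beyond the scatter) matching in size the earlier 3.0-fold higher number from compound 1 to compound 2 (0.48 log units; beyond the scatter) and showing that the number lies higher with either halogen than with tert-butyl, a result that no longer rests on chloro alone. Nothing shown here gives a measured reason for these numbers.

The compounds shown leave open whether the agreement between chloro and bromo extends to fluoro or iodo at the same place, and whether the distance between the halogens and tert-butyl follows the size of the group or something else. They also leave open how an amine, a carboxylic acid or a longer alkyl chain at this place would compare with tert-butyl, and whether any such group would bring the dose lower than that of compound 1.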